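Nitrile to chloro on the shared core

This account rests on a few compounds, and the source may have more. Where it says the series, first, only, none or still open, it means among the compounds named here.

Measured in an ADME assay on H1-HeLa cells (Homo sapiens) for cytotoxicity, read by MTT assay, with a stated time of 3 days; a higher number here means that more compound is tolerated, a lower number that less compound is tolerated:
- compound 1 `CCOC(=O)c1sc2cc(Oc3ccnc(C(=O)NC)c3)ccc2c1C`: 50900 nM
- compound 2 `CCOC(=O)c1sc2cc(Oc3ccnc(C(=O)NC)c3)ccc2c1C#N`: > 100000 nM

Compound 2 gives only a limit, > 100000 nM, and no number. Compound 3 `CCOC(=O)c1sc2cc(Oc3ccnc(C(=O)NC)c3)ccc2c1Cl` differs from it at one place: chloro in place of cyano on an aromatic carbon. Going by the values given here, the one measured step at this place is an at least 1.9-fold higher number from compound 1 to compound 2 (0.29 log units; that floor lies within the scatter), and it gives only a floor. With compound 1 at 50900 nM, a small change in this assay is expected, towards a lower number if any, and possibly none beyond the scatter. The expected change is an at least 1.4-fold lower number from compound 2 to compound 3 (0.15 log units; that floor lies within the scatter). Compound 3 is estimated at 70000 nM, within an expected range of 30000 nM to 130000 nM.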

Compound 3, half-maximal cytotoxic concentration: 46900 nM
Estimate against measurement, compound 3: 1.5-fold (0.17 log units) above; measured number inside the range.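

In this assay chloro in place of methyl on this aromatic carbon leaves the two compounds within the scatter (a 1.1-fold lower number from compound 1 to compound 3 (0.04 log units; within the scatter)). Chloro in place of cyano gives the first step at this position that is printed as beyond the scatter (an at least 2.1-fold lower number from compound 2 to compound 3 (0.32 log units; beyond the scatter)). That step is only a floor, because compound 2 gives a limit and not a number: the limit of > 100000 nM in this assay, at which 1 of the 3 values shown sits.

On these data alone, how far compound 2 lies past its limit stays open. Also open, as far as these compounds go, is whether an amine or a carboxylic acid on this aromatic carbon would stay with compound 1 and compound 3 or move towards compound 2.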